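The source may hold more compounds than are shown below. What is called first, only, known or untested is meant among the compounds shown, and "the series" means these compounds.

Compound 1 `COC(=O)/C=C/c1cccc(N(Cc2ccc(/C=C/C(=O)OC(C)(C)C)cc2OC(C)=O)C(=O)C2CCCCC2)c1` gives > 1000 nM in an assay on isolated protein with Bile acid receptor (Homo sapiens) as the target (a lower number here means that less compound is needed, a higher number that more compound is needed for the effect), a limit of the assay.
Compound 2 `COC(=O)/C=C/c1cccc(N(Cc2ccc(/C=C/C(=O)OC(C)(C)C)cc2OS(C)(=O)=O)C(=O)C2CCCCC2)c1` gives > 1000 nM in this assay, likewise a limit.

Compound 2 stands only at a limit; the limit of > 1000 nM in this assay, at which 2 of the 2 values shown sit, holds every value shown, so the step that the two limits leave unreadable from compound 1 to compound 2 is unreadable in size and direction. Compound 3 `COC(=O)/C=C/c1cccc(N(Cc2ccc(/C=C/C(=O)OC(C)(C)C)cc2O)C(=O)C2CCCCC2)c1` differs from compound 2 by hydrogen in place of methylsulfonyl on an oxygen on an aromatic ring. Going by the values given here, no measured step bears on this change, and no measured number sits on either side of it; nothing here points to a direction beyond the scatter. The expected step is a step that the limit leaves unreadable from compound 2 to compound 3, with a wide uncertainty. Compound 3 is estimated at 1200 nM, in a range from 150 nM to 10000 nM.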

Compound 3, half-maximal effective concentration: > 1000 nM
Compound 3 gave a limit, no number; the forecaster's own chance of this, stated with the estimate: 55%; the middle value does not contradict the limit.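

No new step can be read among compound 1, compound 2 and compound 3, since each gives only a limit of the assay: the limit of > 1000 nM in this assay, at which 3 of the 3 values shown sit.

The compounds shown leave open whether acetyl, methylsulfonyl or hydrogen on this oxygen makes any difference.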